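This account rests on a few compounds, and the source may have more. Where it says the series, first, only, none or still open, it means among the compounds named here.

Compound 2 `COc1cc(C2=NN(C(C)=O)C(c3cccc(OC)c3OC)O2)cc(OC)c1OC` is the stronger of the two compounds measured in a functional assay on PC-3 cells (Homo sapiens) for antiproliferative activity, read by MTT assay, tested at 5 uM; a lower number here means a weaker effect, a higher number a stronger effect of the compound at the concentration tested: in that assay compound 2 gives 58.2%. Among the measured compounds shown here, compound 1 `COc1cc(C2=NN(C(C)=O)C(c3c(Cl)cccc3Cl)O2)cc(OC)c1OC`, the only other compound with a number, gives in this assay a read-out of -2.2%. For the measured compounds named here, the single measured step runs between these two and is large, a number 60.4 percentage points higher from compound 1 to compound 2 (beyond the scatter), which shows that the group on the saturated ring carbon matters a great deal for the read-out.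

Compound 3 `COc1ccc(OC)c(C2OC(c3cc(OC)c(OC)c(OC)c3)=NN2C(C)=O)c1` is not yet measured. It differs from compound 2 in one place: 2,5-dimethoxyphenyl in place of 2,3-dimethoxyphenyl on a saturated ring carbon. Going by the values given here, no measured step covers a rearrangement of the two methoxy groups on the same ring; the one step on record compares a dichlorophenyl with a dimethoxyphenyl, not two dimethoxyphenyls. The change from compound 2 to compound 3 is therefore expected to be smaller than the step from compound 1 to compound 2, with a modest loss more likely than a gain, estimated as a number 16.2 percentage points lower from compound 2 to compound 3 (beyond the scatter). Compound 3 is accordingly expected to give about 42% in this assay, in a range from 12% to 68%.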

Compound 3, a percentage reported as inhibition, at one concentration (the size of the read-out at that concentration, not a potency): 43.2%
For compound 3 the middle estimate is 1.2 percentage points below the measured one; low and high end bracket the measured number.
By their numbers in this assay, from the lowest: compound 1; then compound 3; then compound 2.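

In this assay, putting 2,5-dimethoxyphenyl in place of 2,3-dimethoxyphenyl on the saturated ring carbon gives a number 15 percentage points lower from compound 2 to compound 3 (beyond the scatter), so two groups with the same atoms and the same counted features do not read the same, and the arrangement of the two methoxy groups on the ring counts at this position. Measured against the 2,6-dichlorophenyl group, the 2,5-dimethoxyphenyl group still gives a number 45.4 percentage points higher from compound 1 to compound 3 (beyond the scatter), so the large gain seen earlier is not confined to a single methoxy arrangement, though the rearrangement step is modest beside it. Nothing available gives a reason for either step.

The compounds shown leave open how a phenyl ring with a single methoxy group, a hydroxyl group or an amine on this carbon would read in this assay, and whether the low read-out of the 2,6-dichlorophenyl compound belongs to the chlorine atoms themselves or to their arrangement on the ring. Going by these compounds, the acetyl group is also the same in all three compounds, so the effect of a longer acyl chain such as propanoyl remains open.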